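The source may hold more compounds than are shown below. What is called first, only, known or untested is meant among the compounds shown, and "the series" means these compounds.

In a functional assay on COLO 205 cells (Homo sapiens) for cytotoxicity, read by sulforhodamine B assay, with a stated time of 48 h (on this read-out higher numbers stand for lower toxicity in this test and lower numbers for higher toxicity in this test), compound 1 `ClCc1cccc(Cn2cnc3c(Cl)ncnc32)c1` gives 74100 nM. Compound 2 `ClCc1cccc(Cn2cnc3c(Cl)nc(Cl)nc32)c1` differs from compound 1 by a chloro in place of hydrogen on an aromatic carbon. In this assay compound 2 reaches only a limit, > 100000 nM. Among the measured compounds shown here, its standing therefore rests on (the limit of > 100000 nM in this assay, at which 1 of the 2 values shown sits), and the step of an at least 1.3-fold higher number from compound 1 to compound 2 (0.13 log units; that floor lies within the scatter) tells only that compound 2 is not more toxic than compound 1 by any amount beyond the scatter. Compound 3 `Nc1nc(Cl)c2ncn(Cc3cccc(CCl)c3)c2n1` carries amino in place of chloro on an aromatic carbon. No measured step exchanges a chloro for an amino; the single step shown, from hydrogen to chloro, does not bear directly on this change, so no direction beyond the scatter can be drawn from it. With compound 2 already at a limit, compound 3 is expected to remain weak in this assay, with an estimated value of 100000 nM and a likely range from 30000 nM to 300000 nM. The estimated step of a number no higher from compound 2 to compound 3 (the limit leaves the size open) is thus expected to be essentially none.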

Compound 3, concentration lethal to 50% of the cells: 97700 nM
For compound 3 the middle estimate is 1.0-fold (0.01 log units) above the measured one; low and high end bracket the measured number.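

On the aromatic carbon between two ring nitrogen atoms, amino gives compound 3 a measured number in this assay, and the step from chloro is an at least 1.0-fold lower number from compound 2 to compound 3 (0.01 log units; that floor lies within the scatter), so this exchange does not separate the two compounds beyond the scatter. Hydrogen at the same place can now also be set beside amino, and the reading is a 1.3-fold higher number from compound 1 to compound 3 (0.12 log units; within the scatter), so in this test hydrogen and amino cannot be told apart there. The value of compound 2 is a limit, which leaves the comparison with chloro open on one side: the limit of > 100000 nM in this assay, at which 1 of the 3 values shown sits.

As far as these compounds go, whether any group on this carbon could move the number beyond the scatter remains open, for example a methoxy group, a methylamino group or a longer chain. Also open, from the compounds shown here alone, is whether a thiol or an amine in place of the chloro group retained on the core by all three compounds would read differently.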